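Trimming the nitrile: from compound 3 to compound 4

This account rests on a few compounds, and the source may have more. Where it says the series, first, only, none or still open, it means among the compounds named here.

Compounds measured so far:
- compound 1 `CS(=O)(=O)c1ccc(-c2cnc3[nH]cc(-c4nnc(-c5ccc(Cl)cc5)o4)c(=O)c3c2)cc1`: 26.8%
- compound 2 `Cc1ccc(-c2nnc(-c3c[nH]c4ncc(-c5ccc(S(C)(=O)=O)cc5)cc4c3=O)o2)cc1`: 11.2%
- compound 3 `N#Cc1ccc(-c2cnc3[nH]cc(-c4nnc(-c5ccc(Cl)cc5)o4)c(=O)c3c2)cc1`: 12.5%

All three share one core and differ only in the groups on the two outer benzene rings. In a functional assay on A549 cells (Homo sapiens) for inhibition, read by MTT assay, with a stated time of 24 h, tested at 10 uM (a lower number here means less inhibition of growth, a higher number more inhibition of growth at the concentration tested), compound 3 stands second highest of the three numbers, but its gap to compound 2 lies within the scatter; only compound 1 sits clearly higher, as the step of a number 14.3 percentage points lower from compound 1 to compound 3 (beyond the scatter) shows.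

Compound 4 `O=c1c(-c2nnc(-c3ccc(Cl)cc3)o2)c[nH]c2ncc(-c3ccccc3)cc12` is not yet measured. It differs from compound 3 by hydrogen in place of cyano on an aromatic carbon. Of the measured steps, a number 14.3 percentage points lower from compound 1 to compound 3 (beyond the scatter) touches the same aromatic carbon, while a number 15.6 percentage points lower from compound 1 to compound 2 (beyond the scatter) concerns the other ring. Among the compounds with values here, both steps lowered the number, and the first removed a larger group for a smaller one at this very place. Taking hydrogen in place of cyano as one more paring-down, a step in this assay of a number 3.5 percentage points lower from compound 3 to compound 4 (within the scatter) is expected, small enough to fall within the scatter. Compound 4 is therefore estimated at 9%, with a range from 0% to 22%.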

Compound 4, percent growth inhibition at one concentration: 9.77%
Estimate against measurement, compound 4: 0.8 percentage points below, within the range that was stated.
By their numbers in this assay, from the lowest: compounds 4, 2 and 3 (each within the scatter of the next); then compound 1.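

In this assay, within the data shown here, the 4-cyanophenyl to phenyl change gives a number 2.7 percentage points lower from compound 3 to compound 4 (within the scatter), so cyano and hydrogen on this aromatic carbon cannot be told apart, and the bare phenyl now provides a reference that the earlier compounds lacked. Against that reference, a number 17 percentage points lower from compound 1 to compound 4 (beyond the scatter) shows that, of the three groups tried at this place, only methylsulfonyl stands clearly apart from hydrogen. No measurement among these data explains why methylsulfonyl stands apart here.

As far as these compounds go, what remains open is whether the higher number belongs to methylsulfonyl alone or would also appear with another group on this carbon, such as an amine, a carboxylic acid or a longer chain. Also open, from the compounds shown here alone, is how any of these groups would behave with the other ring's chloro group replaced by something else.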